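The source may report more compounds than this note shows. Statements on the series, on what has been measured and on what is new or still open speak of the compounds shown alone.

Working notes on the ester series.

Compound 1 `CC(=O)Oc1ccccc1C(=O)O[C@H]1CO[C@H]2[C@@H]1OC[C@H]2OC(C)=O` is the reference here. In an ADME assay on a cell-free system (plasma, Homo sapiens) for metabolic stability, with Plasma (Rattus norvegicus) as the target, read by HPLC, at pH 7.4 (a lower number here means that the compound disappears faster, a higher number that the compound lasts longer), compound 1 gives 0.0095 h, the lowest of the two numbers recorded; its nearest neighbour is compound 2 `CC(=O)Oc1ccccc1C(=O)O[C@H]1CO[C@H]2[C@@H]1OC[C@H]2OC(=O)c1cccc(C)c1`, which in this assay gives 0.0203 h. Among the measured compounds shown here, the single step recorded so far, a 2.1-fold higher number from compound 1 to compound 2 (0.33 log units; beyond the scatter), is a modest rise that comes from putting 3-methylphenyl in place of methyl on a carbonyl carbon.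

Compound 3 `CC(=O)Oc1ccccc1C(=O)O[C@H]1CO[C@H]2[C@@H]1OC[C@H]2OC(=O)CO[N+](=O)[O-]` is the next member to be measured in this assay. It differs from compound 1 as follows: nitrooxy in place of hydrogen on a saturated chain carbon bound to a carbonyl carbon. The change sits on the same acetyl group that the step to compound 2 replaced, but it keeps the methyl-derived carbon and adds nitrooxy to it rather than exchanging the whole group for an aryl ring. For the measured compounds named here, no recorded step therefore bears directly on this change; the step to compound 2 only shows that alterations at this carbonyl can move the half-life modestly.

With nothing closer to go on, the expectation for compound 3 is a number near that of compound 1, with any shift likely within the scatter, a 1.1-fold higher number from compound 1 to compound 3 (0.02 log units; within the scatter). The estimate for compound 3 in this assay is 0.01 h, with a range from 0.004 h to 0.03 h.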

Compound 3, half-life: 0.015 h
Compound 3: middle estimate off by 1.5-fold (0.18 log units), on the low side, and the stated range covers the measured number.
By their numbers in this assay, from the lowest: compounds 1, 3 and 2 (each within the scatter of the next, the first and the last beyond it).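

In this assay, adding nitrooxy on a saturated chain carbon bound to a carbonyl carbon gives a 1.6-fold higher number from compound 1 to compound 3 (0.20 log units; within the scatter), so this change at the acetyl group does not move the half-life clear of the usual variation between repeats. Among the compounds shown here, exchanging 3-methylphenyl for (nitrooxy)methyl on the same carbonyl carbon gives a 1.4-fold lower number from compound 2 to compound 3 (0.13 log units; within the scatter), which means that compound 3 cannot be separated from either neighbour, even though a 2.1-fold higher number from compound 1 to compound 2 (0.33 log units; beyond the scatter) remains the only step in this set that stands beyond the scatter. For the compounds shown here, nothing available explains the half-life at this position, and the series so far offers only these numbers.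

Whether a longer chain, an amine or a carboxylic acid on this same saturated chain carbon would shift the half-life beyond the scatter remains open, as the only substituent shown there is nitrooxy. The rest of the core of compound 1 is also common to all three compounds, so the contribution of the other parts of the molecule to the half-life in this assay remains unresolved.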